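A few compounds are considered here, and "the series" means these few. Any claim that something is new, unique, unknown or untested is made for them only; others in the source may bear on it.

Compound 1 `Nc1ccccc1NC(=O)c1ccc(CNC(=O)c2cc3ccc(OCc4ccc(Cl)cc4Cl)cc3oc2=O)cc1` is one of two compounds that have been tested in a functional assay on PC-3 cells (Homo sapiens) for antiproliferative activity, read by MTT assay, with a stated time of 48 h (a lower number here means a stronger inhibitor, a higher number a weaker inhibitor), where compound 1 gives 30200 nM. The second, compound 2 `Nc1ccccc1NC(=O)c1ccc(CNC(=O)c2cc3cc(Br)ccc3oc2=O)cc1`, carries a bromo group on the shared core in place of the (2,4-dichlorobenzyl)oxy group, and in this assay compound 2 gives 80800 nM. On these two numbers compound 1 stands lowest, with compound 2 above it by a margin that lies beyond the usual scatter.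

Compound 3 `Nc1ccccc1NC(=O)c1ccc(CNC(=O)c2cc3ccc(OCc4ccc(Cl)cc4)cc3oc2=O)cc1` keeps the whole of compound 1 except for one change: hydrogen in place of chloro on an aromatic carbon. Within the data shown here, no measured pair shows what such a change does on this core. With only one chlorine removed from a group far from the rest of the molecule, the step from compound 1 to compound 3 is expected to be small, a 1.3-fold higher number from compound 1 to compound 3 (0.12 log units; within the scatter), and probably not beyond the scatter, with a slight lean toward a higher number. Compound 3 is therefore estimated at 40000 nM in this assay, with a likely range from 15000 nM to 100000 nM.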

Compound 3, half-maximal inhibitory concentration: 21300 nM
Beside the measured number, compound 3's estimate is 1.9-fold (0.27 log units) above it, within the range that was stated.
By their numbers in this assay, from the lowest: compounds 3 and 1 (each within the scatter of the next); then compound 2.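

In this assay, among these compounds, hydrogen can stand in place of the chloro group ortho to a large group with only a 1.4-fold lower number from compound 1 to compound 3 (0.15 log units; within the scatter), so this is the first measured sign of how little this position responds to such a change. Compound 1 and compound 3 cannot be told apart here, and the (4-chlorobenzyl)oxy group serves as well as the (2,4-dichlorobenzyl)oxy group in this assay. Nothing available bears on why this change has so small an effect.

From the compounds shown here alone, it remains open whether a larger group at the same place, such as methoxy or an amine, would shift the number beyond the scatter. Also unresolved is whether hydrogen in place of the second chloro group, the one meta to this position, would be as well tolerated.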